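This account rests on a few compounds, and the source may have more. Where it says the series, first, only, none or still open, it means among the compounds named here.

Within the data shown here, in a functional assay on DLD-1 cells (Homo sapiens) for cytotoxicity, with a stated time of 48 h (on this read-out lower numbers stand for stronger inhibition and higher numbers for weaker inhibition), compound 1 (`CCOc1ccc2oc(/C=C/[S+](C)[O-])cc(=O)c2c1`) gives 4900 nM and compound 2 (`CC(C)COc1ccc2oc(/C=C/[S+](C)[O-])cc(=O)c2c1`) gives 5000 nM so compound 2 stands level with the only other measured compound. Among the measured compounds shown here, the single measured step is a 1.0-fold higher number from compound 1 to compound 2 (0.01 log units; within the scatter) and it concerns only the end of the chain on the oxygen. Compound 3 (`C[S+]([O-])/C=C/c1cc(=O)c2ccccc2o1`) follows from compound 2 through hydrogen in place of isobutoxy on an aromatic carbon with hydrogen in place of isobutoxy on an aromatic carbon. The measured step bears on this change only loosely. Both measured compounds keep a chain on the oxygen, and none lacks it. Resting on compound 2 at 5000 nM no large shift is expected in this assay in either direction, though the uncertainty is wide. The expected step is a 1.2-fold higher number from compound 2 to compound 3 (0.08 log units; within the scatter) and so stays within the scatter. Compound 3 is estimated at 6000 nM with an expected range from 2000 nM to 20000 nM as its likely span.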

Compound 3, half-maximal inhibitory concentration: 8000 nM
Compound 3: middle estimate off by 1.3-fold (0.12 log units), on the low side; the measured number falls inside the stated range.
By their numbers in this assay, from the lowest: compounds 1, 2 and 3 (each within the scatter of the next).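

In this assay the step with hydrogen in place of isobutoxy is a 1.6-fold higher number from compound 2 to compound 3 (0.20 log units; within the scatter) and the step with hydrogen in place of ethoxy is a 1.6-fold higher number from compound 1 to compound 3 (0.21 log units; within the scatter) so this aromatic carbon can carry no chain at all without a change that stands beyond the scatter. The earlier compounds shown here differed only at the end of the chain on the oxygen, whereas these steps remove the whole chain, and the read-out still does not separate the compounds with a chain from the one without. No evidence is at hand that would explain these numbers.

On these data alone, what remains open is whether a different kind of group on this aromatic carbon, such as an amine, a fluorine atom or a carboxylic acid, would move the number beyond the scatter. As far as these compounds go, whether a change elsewhere on the shared core would do so also remains open.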